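The compounds below may be only part of what the source reports. "The series", "measured", "known", "first", "only" and "open" are said of these compounds alone.

Compound 1 `C[C@@H](Nc1c(C(N)=O)cnc2ccc(-c3cccnc3)cc12)C1CCOCC1`: 46 uL/min
Compound 2 `CCC(CC)CNc1c(C(N)=O)cnc2ccc(-c3ccc(COC)cc3)cc12`: 76 uL/min
Compound 3 `CCC(CC)CNc1c(C(N)=O)cnc2ccc(-c3ccc(CS(C)(=O)=O)cc3)cc12`: 210 uL/min

In an ADME assay on cells (Hepatocyte, Rattus norvegicus) for metabolic stability, with a stated time of 90 min (a lower number here means slower removal, a higher number faster removal of the compound), compound 2 gives 76 uL/min, the second highest of the three numbers; compound 1, at 46 uL/min, sits within the scatter of it, while compound 3, at 210 uL/min, sits beyond it. Compound 4 `CCC(CC)CNc1c(C(N)=O)cnc2ccc(-c3ccc(CO)nc3)cc12` has not yet been measured. Its change from compound 2 is 6-(hydroxymethyl)pyridin-3-yl in place of 4-(methoxymethyl)phenyl on an aromatic carbon. Within the data shown here, the only measured step, a 2.8-fold higher number from compound 2 to compound 3 (0.44 log units; beyond the scatter), kept the same aromatic ring and swapped a group on it; no measured step exchanges the ring itself, so the data give no direct guide. The step to compound 4 is therefore expected to be a 1.3-fold lower number from compound 2 to compound 4 (0.10 log units; within the scatter), with no change beyond the scatter in either direction. Compound 4 is estimated at 60 uL/min, in the range 30 uL/min to 120 uL/min.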

Compound 4, intrinsic clearance in a liver preparation (reported as CLH), per the amount of preparation that the assay uses: > 300 uL/min
Compound 4: no number, only a limit; the forecaster's own chance of this, stated with the estimate: 5%; middle value at least 5.0-fold (0.69 log units) from the limit.
By their numbers in this assay, from the lowest: compounds 1 and 2 (each within the scatter of the next); then compound 3. At a limit, above all of these: compound 4.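

The earlier compounds shown here only swapped a group on the same ring, whereas this change exchanges the ring itself at this aromatic carbon, and in this assay it gives an at least 3.9-fold higher number from compound 2 to compound 4 (0.59 log units; beyond the scatter). For compound 4 the value is a limit of the assay and not a number: > 300 uL/min. The true size of the step therefore stays open on its upper side: the limit of > 300 uL/min in this assay, at which 1 of the 4 values shown sits.

The ring and its side group change together, so the compounds shown cannot say which of the two carries the step. A 4-(hydroxymethyl)phenyl or a 6-(methoxymethyl)pyridin-3-yl group at this place would separate them.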